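Changing the difluoro group of a slowly cleared compound

The source may report more compounds than this note shows. Statements on the series, on what has been measured and on what is new or still open speak of the compounds shown alone.

In an in vitro ADME assay on microsomes (Homo sapiens) for pharmacokinetics (a higher number here means faster removal of the compound, a lower number slower removal), compound 2 `O=C(NC1CC1)c1ccc(CN([C@@H]2CC(F)(F)CCNC2=O)S(=O)(=O)c2ccc(Cl)cc2)cc1` gives the lowest number of three (1.9 mL.min-1.g-1), while compound 1 `COc1ccc(CN([C@@H]2CC(F)(F)CCNC2=O)S(=O)(=O)c2ccc(Cl)cc2)cn1` gives 9 mL.min-1.g-1 (the nearest) and compound 3 `COc1ccc(CN([C@@H]2CC(F)(F)CCNC2=O)S(=O)(=O)c2ccc(Cl)cc2)c(F)c1F` gives 19 mL.min-1.g-1 (the furthest). For the measured compounds named here, compound 4 `CC(C)C1CCNC(=O)C(N(Cc2ccc(C(=O)NC3CC3)cc2)S(=O)(=O)c2ccc(Cl)cc2)C1` has 5-isopropyl-2-oxoazepan-3-yl in place of 5,5-difluoro-2-oxoazepan-3-yl on a sulfonamide nitrogen The only measured step (a 2.1-fold higher number from compound 1 to compound 3 (0.32 log units; beyond the scatter)) is modest and changes a different group. All three measured compounds carry the difluoro group, so nothing measured tests this swap directly. A rise in this assay is therefore expected only tentatively, as a low starting compound has more room to go up (a 3.2-fold higher number from compound 2 to compound 4 (0.50 log units; beyond the scatter)). For compound 4 the expected value is 6 mL.min-1.g-1 (estimated range 2 mL.min-1.g-1 to 20 mL.min-1.g-1).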

Compound 4, intrinsic clearance in microsomes: 51 mL.min-1.g-1
Compound 4: middle estimate off by 8.5-fold (0.93 log units), on the low side, and the stated range ends below it.
By their numbers in this assay, from the lowest: compound 2; then compound 1; then compound 3; then compound 4.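

Until now every compound carried the difluoro group, so this position was untested. In this assay, replacing 5,5-difluoro-2-oxoazepan-3-yl with 5-isopropyl-2-oxoazepan-3-yl gives a 27-fold higher number from compound 2 to compound 4 (1.43 log units; beyond the scatter), so for this pair the group on the sulfonamide nitrogen strongly affects the read-out, although compound 4, unlike compound 2, is drawn without a defined stereocentre. No measurement shown here explains the rise. Still open, on these data alone, is how a methyl or hydroxyl group on this ring would behave. Also open, as far as these compounds go, is whether the same swap would have a similar effect on compound 1 or compound 3.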